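The compounds below may be only part of what the source reports. "The series", "measured", "known", "first", "only" and "open" are said of these compounds alone.

Measured so far, in a functional assay on U-373MG ATCC cells (Homo sapiens) for inhibition, read by colorimetric assay and MTT assay, with a stated time of 72 h; a lower number here means a stronger inhibitor, a higher number a weaker inhibitor: compound 1, `COc1cc(C(=O)NNC(=S)Nc2csc(-c3ccccc3)c2)cc(OC)c1OC`, gives 44000 nM; compound 2, `COc1cc(C(=O)NNC(=S)Nc2csc(-c3ccc(C)cc3)c2)cc(OC)c1OC`, gives 47000 nM; compound 3, `Oc1ccc(-c2nnc(Nc3csc(-c4ccccc4)c3)s2)cc1`, gives 58000 nM.

Compound 2 differs from compound 1 by methyl in place of hydrogen on an aromatic carbon. In this assay this gave a 1.1-fold higher number from compound 1 to compound 2 (0.03 log units; within the scatter). The difference between the core of compound 1 and the core of compound 3 is not broken down here. Compound 4, `Cc1ccc(-c2cc(Nc3nnc(-c4ccc(O)cc4)s3)cs2)cc1`, has not yet been measured; it differs from compound 3 by methyl in place of hydrogen on an aromatic carbon, the same change that turns compound 1 into compound 2. Because the step of a 1.1-fold higher number from compound 1 to compound 2 (0.03 log units; within the scatter) shows hardly any movement on the core of compound 1, a step of similar size, a 1.1-fold higher number from compound 3 to compound 4 (0.03 log units; within the scatter), is expected on the core of compound 3. Compound 4 is therefore expected to give about 62000 nM in this assay, most likely between 30000 nM and 125000 nM.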

Compound 4, half-maximal inhibitory concentration: 8000 nM
For compound 4 the middle estimate is 7.8-fold (0.89 log units) above the measured one; the whole stated range lies above it.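

In this assay, going from phenyl to 4-methylphenyl gives a 7.3-fold lower number from compound 3 to compound 4 (0.86 log units; beyond the scatter). The same small change therefore does not carry over with the same size from one core to the other: the same change on two cores in this assay, a 1.1-fold higher number (0.03 log units; within the scatter) from compound 1 to compound 2 and a 7.3-fold lower number (0.86 log units; beyond the scatter) from compound 3 to compound 4, 7.7-fold (0.89 log units) apart, beyond the scatter of two such steps This shows that a step measured on one core in this series cannot simply be copied to another, but two pairs cannot show which part of the cores makes the difference, or why.

The compounds shown leave open whether an ethyl group or a chlorine atom in place of the methyl would move the number on the core of compound 3. They also leave open how the methyl would behave on any further core.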